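Aromatic substituent exchange on a shared core

A few compounds are considered here, and "the series" means these few. Any claim that something is new, unique, unknown or untested is made for them only; others in the source may bear on it.

In a functional assay on the whole organism for inhibition, with Mus musculus as the target, in the maximal electroshock model, at a dose of 30 mg/kg by the oral route (a higher number here means a stronger effect of the compound at the dose given, a lower number a weaker effect), compound 3 `COc1ccc(N2C(=O)NC3(CC3(C)C)C2=O)cc1` gives 60%. Among the three measured compounds, compound 1 `CN1C(=O)NC2(CC2(C)C)C1=O` gives 90%, a gap beyond the scatter above compound 3, while compound 2 `Cc1ccc(N2C(=O)NC3(CC3(C)C)C2=O)cc1` gives 50%, within the scatter of compound 3. Compound 4 `CC1(C)CC12NC(=O)N(c1ccc([N+](=O)[O-])cc1)C2=O` differs from compound 3 by nitro in place of methoxy on an aromatic carbon. Among the measured compounds shown here, the one measured step at the same place on the aromatic ring is a number 10 percentage points higher from compound 2 to compound 3 (within the scatter), and it lies within the scatter; no other step on the ring substituent is known. On that basis no step beyond the scatter is expected, no change at the digits printed from compound 3 to compound 4 (within the scatter). Compound 4 is estimated at 60% in this assay, with a range from 40% to 80%.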

Compound 4, a percentage reported as inhibition, in the whole organism at one dose (the size of the read-out at that dose, not a potency): 60%
The estimate for compound 4 equals the measured number at the digits printed; the measured number falls inside the stated range.
By their numbers in this assay, from the lowest: compounds 2, 3 and 4 (each within the scatter of the next); then compound 1.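

In this assay nitro in place of methoxy gives no change at the digits printed from compound 3 to compound 4 (within the scatter) and nitro in place of methyl gives a number 10 percentage points higher from compound 2 to compound 4 (within the scatter) at this position. Nitro, with more heavy atoms and more hydrogen-bond acceptors than methoxy, thus joins methyl and methoxy on this aromatic carbon with no step beyond the scatter, which the single earlier step could not show. Nothing measured here offers a reason for this flat reading. Open, as far as these compounds go, is whether an amine or a carboxylic acid at this same place would give a step beyond the scatter.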